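The compounds below may be only part of what the source reports. "The series", "measured", "known", "first", "only" and "open" are said of these compounds alone.

Measured so far: compound 1 `O=c1cc(-c2ccccc2)oc2cc(OCCCCNc3nc4ccccc4s3)cc(O)c12` gives 14.6 ug/mL in a functional assay on Ca-Ski cells (Homo sapiens) for cytotoxicity, read by sulforhodamine B assay, with a stated time of 48 h; a higher number here means a weaker inhibitor, a lower number a stronger inhibitor; compound 2 `Cc1ccc2nc(NCCCCOc3cc(O)c4c(=O)cc(-c5ccccc5)oc4c3)sc2c1` gives 15.5 ug/mL in this assay.

Compound 2 holds the higher of the two numbers, yet the gap a 1.1-fold higher number from compound 1 to compound 2 (0.03 log units; within the scatter) lies within the scatter. Compound 3 `O=c1cc(-c2ccccc2)oc2cc(OCCCCNc3nc4ccc([N+](=O)[O-])cc4s3)cc(O)c12` differs from compound 2 by nitro in place of methyl on an aromatic carbon. For the measured compounds named here, the one measured step, a 1.1-fold higher number from compound 1 to compound 2 (0.03 log units; within the scatter), introduced the methyl that now leaves and stayed within the scatter; nothing measured bears on a nitro group. The author therefore expects no step beyond the scatter, a 1.0-fold lower number from compound 2 to compound 3 (0.01 log units; within the scatter). For compound 3 the estimate is 15 ug/mL, with a range of 5 ug/mL to 45 ug/mL.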

Compound 3, half-maximal inhibitory concentration: 13.2 ug/mL
The estimate for compound 3 lay 1.1-fold (0.06 log units) above the measured number; the range from low to high includes it.
By their numbers in this assay, from the lowest: compounds 3, 1 and 2 (each within the scatter of the next).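

Nitro on this aromatic carbon gives a step no larger than the methyl did: (a 1.2-fold lower number from compound 2 to compound 3 (0.07 log units; within the scatter)) and (a 1.1-fold lower number from compound 1 to compound 3 (0.04 log units; within the scatter)) in this assay. Hydrogen, methyl and nitro at this place therefore cannot be told apart in this assay, although nitro brings more heavy atoms and 2 hydrogen-bond acceptors, where methyl brings none. No evidence is available on what lies behind this. The compounds shown leave open whether an amine or a carboxylic acid at this place would also stay within the scatter, and what a longer chain would do.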